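Methyl for hydrogen on the aryl ring of compound 2

The source may report more compounds than this note shows. Statements on the series, on what has been measured and on what is new or still open speak of the compounds shown alone.

Compound 2 `O=C(Oc1cccc(Cl)c1)c1cc2ccccc2oc1=O` gives the lower of the two numbers in a functional assay on HT-1080 cells (Homo sapiens), read by transwell migration, with a stated time of 24 h, tested at 1 uM (a higher number here means a weaker effect of the compound at the concentration tested, a lower number a stronger effect), at 45.5%; compound 1 `O=C(Oc1cccc(Cl)c1)c1cc2cc([N+](=O)[O-])ccc2oc1=O` gives 65.8%. Going by the values given here, the one measured step, a number 20.3 percentage points lower from compound 1 to compound 2 (beyond the scatter), swaps nitro for hydrogen, not hydrogen for methyl. Compound 3 `Cc1ccc2oc(=O)c(C(=O)Oc3cccc(Cl)c3)cc2c1` differs from compound 2 by methyl in place of hydrogen on an aromatic carbon. Among the compounds with values here, no measured step bears directly on this change, so no shift beyond the scatter is expected in this assay, with a wide range. The estimate for compound 3 is 48% (range 30% to 66%), corresponding to an expected step of a number 2.5 percentage points higher from compound 2 to compound 3 (within the scatter).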

Compound 3, a percentage reported as activity, at one concentration (the size of the read-out at that concentration, not a potency): 52.5%
For compound 3 the middle estimate is 4.5 percentage points below the measured one; the range from low to high includes it.
By their numbers in this assay, from the lowest: compounds 2 and 3 (each within the scatter of the next); then compound 1.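

In this assay, the methyl in place of hydrogen gives a number 7 percentage points higher from compound 2 to compound 3 (within the scatter) and so leaves the read-out at this position within the scatter of the unsubstituted compound. Replacing nitro with methyl gives a number 13.3 percentage points lower from compound 1 to compound 3 (beyond the scatter) at the same place, so among these three compounds only nitro stands apart, with hydrogen and methyl level. Nothing available explains why methyl and nitro differ here.

As far as these compounds go, whether a chlorine, a methoxy group or an amine at this position would read with hydrogen and methyl or with nitro remains open. Also open, from the compounds shown here alone, is whether a longer chain than methyl would stay within the scatter of compound 2.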